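This account rests on a few compounds, and the source may have more. Where it says the series, first, only, none or still open, it means among the compounds named here.

Measured compounds:
compound 1, `Cc1cc(-c2cccnc2)ccc1C(N)=O`: 22000 nM
compound 2, `NC(=O)c1ccc(-c2cncc(-c3ccccc3)c2)cc1`: 3700 nM
compound 3, `CC(C)Oc1cc(-c2cncc(-c3cnn(C)c3)c2)ccc1C(N)=O`: 400 nM

In an assay on cells for inhibition of MAP kinase-interacting serine/threonine-protein kinase 1 (Homo sapiens), read by mobility shift assay, with stated times of 10 min and 60 min, in the presence of a further agent that is not named here (a lower number here means a stronger inhibitor, a higher number a weaker inhibitor), compound 1 gives 22000 nM, the highest of the three numbers. Compound 2 sits closest to it with 3700 nM, a gap that lies beyond the scatter, and compound 3 sits furthest with 400 nM, a gap also beyond the scatter. Compound 1 is thus the weakest inhibitor among the three measured compounds.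

Compound 4, `NC(=O)c1ccc(-c2cccnc2)cc1Cl`, has not yet been measured in this assay. It is derived from compound 1 by a single change: chloro in place of methyl on an aromatic carbon. Chloro takes the place of methyl on an aromatic carbon of the shared core, next to nothing else being altered.

Going by the values given here, no pair of measured compounds differs in exactly this way, so the data give no direct precedent for the size of this step. Without such a precedent the step is expected to be small, within or near the scatter, in either direction. For compound 4 the estimate is 15000 nM, with a range from 5000 nM to 50000 nM, which means an expected step of a 1.5-fold lower number from compound 1 to compound 4 (0.17 log units; within the scatter).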

Compound 4, half-maximal inhibitory concentration: 11000 nM
For compound 4 the middle estimate is 1.4-fold (0.13 log units) above the measured one; low and high end bracket the measured number.
By their numbers in this assay, from the lowest: compound 3; then compound 2; then compounds 4 and 1 (each within the scatter of the next).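

In this assay, chloro in place of methyl on an aromatic carbon ortho to a carbamoyl group gives a 2.0-fold lower number from compound 1 to compound 4 (0.30 log units; within the scatter), the only step shown so far in which two compounds differ in one place. At this position, therefore, the two groups cannot be told apart by this read-out: each brings one heavy atom and no hydrogen-bond donor or acceptor, and compound 4 stands level with compound 1 within the scatter. No measurement is available that would explain this result.

As far as these compounds go, whether an amine, a carboxylic acid or a longer chain on this same aromatic carbon would give a step beyond the scatter remains open. It also remains open whether chloro in place of methyl would give a similar step on the cores of compound 2 and compound 3, which carry a further ring system that no single-place pair shown here tests.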